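A few compounds are considered here, and "the series" means these few. Any claim that something is new, unique, unknown or untested is made for them only; others in the source may bear on it.

Compound 1, `COc1cc2c(cc1N1C[C@@H](C)N[C@@H](C)C1)N(S(=O)(=O)c1ccc3ccccc3c1)CC2`, and compound 2, `COc1cc2c(cc1N1CCN[C@H](C)C1)N(S(=O)(=O)c1ccc(-c3ccccn3)s1)CC2`, were both examined in a functional assay with growth hormone secretagogue receptor type 1 (Homo sapiens) as the target; a lower number here means a smaller maximal response, a higher number a larger maximal response. In this assay compound 1 gives 1, and compound 2 gives 1, so compound 2 stands level with compound 1 at the digits recorded, the two values falling within the usual scatter of each other. Neither compound falls short of the reference agonist's largest response.

Compound 3, `COc1cc2c(cc1N1C[C@@H](C)NC(C)(C)C1)N(S(=O)(=O)c1ccc(-c3ccccn3)s1)CC2`, has not been measured in this assay. It differs from compound 2 in one place: a group of 9 heavy atoms (7 carbon, 2 nitrogen; one six-membered non-aromatic ring with 2 hetero atoms) in place of a group of 7 heavy atoms (5 carbon, 2 nitrogen; one six-membered non-aromatic ring with 2 hetero atoms), on an aromatic carbon. Among the measured compounds shown here, no measured pair in this set carries that kind of change, so nothing is known directly about what it does to the maximal response.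

For the measured compounds named here, on the evidence available, the step from compound 2 to compound 3 is expected to be a number 0.10 lower from compound 2 to compound 3 (within the scatter), that is, either none beyond the scatter or a modest downward move, since the only related change recorded here, from compound 1 to compound 2, left the maximal response unaltered. Compound 3 is therefore estimated to give 0.9 in this assay, with a range from 0.7 to 1.05.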

Compound 3, intrinsic activity: the largest response reached, as a fraction of the reference agonist's: 0.8
For compound 3 the middle estimate is 0.10 above the measured one; measured number inside the range.
By their numbers in this assay, from the lowest: compound 3; then compounds 1 and 2 (each within the scatter of the next).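

In this assay, among the compounds shown here, putting the group of 9 heavy atoms in place of the 3-methylpiperazin-1-yl group, on the aromatic carbon ortho to a methoxy group, brings a number 0.20 lower from compound 2 to compound 3 (beyond the scatter), and this is the first step in the set that goes beyond the scatter. It shows that the maximal response depends on what this position carries, even though the two groups share a six-membered non-aromatic ring with 2 hetero atoms, the same hydrogen-bond donor and acceptor counts, no net charge and one defined stereocentre. What lies behind the step remains unexplained, since nothing else recorded here bears on it.

The compounds shown leave open whether the maximal response tracks the size of the group at this position, or depends instead on how the ring is substituted. On these data alone, a plain piperazin-1-yl or a morpholin-4-yl group here would test the point, and it also remains open whether the same exchange has a comparable effect when the rest of the molecule differs.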